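The compounds below may be only part of what the source reports. "The series", "measured", "known", "first", "only" and "open" are said of these compounds alone.

Compound 1 `CCCC(=O)C1=C(O)/C(=C/c2ccccc2)N(C(C)=O)C1=O`: in an ADME assay on HEK293 cells (Homo sapiens) for cytotoxicity (a lower number here means that less compound is tolerated, a higher number that more compound is tolerated), compound 1 gives > 32 ug/mL, which is a limit of the assay.
Compound 2 `CCCCCCCCCC(=O)C1=C(O)/C(=C/c2ccccc2)N(C(C)=O)C1=O`: in this assay compound 2 gives > 32 ug/mL, also a limit of the assay.

Compound 2 stands at the limit of > 32 ug/mL in this assay, at which 2 of the 2 values shown sit, so its position in this assay is known only as a limit. The step that the two limits leave unreadable from compound 1 to compound 2 is therefore of unreadable size. Compound 3 `CCCCCCCCCCCCCCCC(=O)C1=C(O)/C(=C/c2ccccc2)N(C(C)=O)C1=O` differs from compound 2 by hexyl in place of hydrogen on a saturated chain carbon, nine bonds along the chain from a carbonyl carbon. Among the compounds with values here, the one step that bears on this change, the chain lengthening recorded as a step that the two limits leave unreadable from compound 1 to compound 2, yields no readable size, and no step beyond the scatter is expected in this assay. Compound 3 is estimated at 32 ug/mL, range 12 ug/mL to 80 ug/mL, the expected step being a number no higher from compound 2 to compound 3 (the limit leaves the size open).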

Compound 3, half-maximal cytotoxic concentration: > 32 ug/mL
Compound 3 was reported as a limit (the forecaster's own chance of this, stated with the estimate: 60%); the middle value lies on the limit itself.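

No step from compound 2 to compound 3 can be read in this assay, as both results are limits: the limit of > 32 ug/mL in this assay, at which 3 of the 3 values shown sit.

The compounds shown leave open whether any chain length in this series reaches a measurable half-maximal cytotoxic concentration, and where it would lie.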